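This account rests on a few compounds, and the source may have more. Where it says the series, first, only, none or still open, it means among the compounds named here.

Of the compounds shown here, three sharing one core have been measured in a functional assay on BXPC-3 cells (Homo sapiens) for antiproliferative activity, read by MTT assay, with a stated time of 24 h; on this read-out higher numbers stand for weaker inhibition and lower numbers for stronger inhibition. Compound 1 `CCn1c(C(=O)NCCNC(=O)OC(C)(C)C)ccc1C(CC)(CC)c1ccc(OCS(=O)(=O)c2ccccc2)c(C)c1` gives > 50000 nM, which is a limit of the assay and not a number. Compound 2 `CCn1c(C(=O)NCCO)ccc1C(CC)(CC)c1ccc(OCS(=O)(=O)c2ccccc2)c(C)c1` gives 19900 nM, and compound 3 `CCn1c(C(=O)N[C@H](C)C(=O)O)ccc1C(CC)(CC)c1ccc(OCS(=O)(=O)c2ccccc2)c(C)c1` gives 20100 nM. Compound 3 therefore stands level with compound 2, the two values lying within the scatter of each other.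

Compound 4 `CCn1c(C(=O)NC2(C(=O)O)CC2)ccc1C(CC)(CC)c1ccc(OCS(=O)(=O)c2ccccc2)c(C)c1` alters compound 3 in one place, with 1-carboxycyclopropyl in place of 1-carboxyethyl on an amide-type nitrogen. The closest measured change lies on that same nitrogen, where 1-carboxyethyl replaced 2-hydroxyethyl, and it gave a 1.0-fold higher number from compound 2 to compound 3 (0.00 log units; within the scatter). The two steps that start at the limit are larger, an at least 2.5-fold lower number from compound 1 to compound 2 (0.40 log units; beyond the scatter) and an at least 2.4-fold lower number from compound 1 to compound 3 (0.39 log units; beyond the scatter), but each removes the 2-((tert-butoxycarbonyl)amino)ethyl group, which compound 4 does not carry. For the measured compounds named here, no measured compound has a ring on this nitrogen, so the evidence is indirect.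

On this basis, no step beyond the scatter is expected in this assay. The estimated change is a 1.0-fold lower number from compound 3 to compound 4 (0.00 log units; within the scatter). For compound 4 the expected value is 20000 nM, with an estimated range of 9000 nM to 45000 nM.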

Compound 4, half-maximal inhibitory concentration: > 50000 nM
Compound 4 gave a limit, no number (the forecaster's own chance of this, stated with the estimate: 15%); middle value at least 2.5-fold (0.39 log units) from the limit.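

In this assay, compound 4 gives > 50000 nM, a limit of the assay and not a number. The earlier compounds had shown no readable change between the two groups on this amide-type nitrogen that lack the tert-butoxycarbonyl group, with a 1.0-fold higher number from compound 2 to compound 3 (0.00 log units; within the scatter), whereas closing the 1-carboxyethyl group into 1-carboxycyclopropyl gives an at least 2.4-fold higher number from compound 3 to compound 4 (0.39 log units; beyond the scatter), and the same comparison against the 2-hydroxyethyl group gives an at least 2.5-fold higher number from compound 2 to compound 4 (0.40 log units; beyond the scatter), so a carboxylic acid on this position does not by itself keep the value of compound 3. The step from compound 1 to compound 4 cannot be read: the limit of > 50000 nM in this assay, at which 2 of the 4 values shown sit.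

The change adds a three-membered ring of carbon and also removes the defined stereocentre, and the compounds shown do not separate these two, which an open-chain 1-carboxy-1-methylethyl group on the same nitrogen would begin to do. Also open, from the compounds shown here alone, is how a larger ring such as 1-carboxycyclobutyl, a longer chain ending in a carboxylic acid, or a free primary amine in place of the protected amine of compound 1 would read on this position.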